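The source may report more compounds than this note shows. Statements on the series, on what has been measured and on what is new or still open speak of the compounds shown alone.

For the measured compounds named here, only two compounds have been measured in a functional assay on RPMI-8226 cells (Homo sapiens) for cytotoxicity, read by fluorescence, with a stated time of 72 h (on this read-out lower numbers stand for stronger inhibition and higher numbers for weaker inhibition), and only one of them gives a number. Compound 1 `Nc1n[nH]c(N)c1/N=N/c1cccc[n+]1[O-]` reaches only a limit of the assay, > 100000 nM. Going by the values given here, compound 2 `Nc1n[nH]c(N)c1/N=N/c1ccc(O)cc1` gives 24900 nM, the only actual number available on this read-out, so it has no second measured value to be ranked against. Compound 3 `CC(=O)n1nc(N)c(/N=N/c2ccc(O)cc2)c1N` keeps the shared core of compound 2 and changes it in one place: acetyl in place of hydrogen on an aromatic nitrogen. This puts acetyl in place of hydrogen on an aromatic nitrogen, next to the ring atom that bears an amino group. Among the compounds with values here, no measured pair shows what such a change does in this assay, so no step beyond the usual scatter is expected, and no direction can be firmly assigned. The expected step is a 1.2-fold lower number from compound 2 to compound 3 (0.10 log units; within the scatter). The estimate for compound 3 is 20000 nM, with an expected range from 6000 nM to 70000 nM.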

Compound 3, half-maximal inhibitory concentration: > 100000 nM
Compound 3 gave a limit, no number; the forecaster's own chance of this, stated with the estimate: 15%; at least 5.0-fold (0.69 log units) between middle value and limit.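

Acetyl in place of hydrogen on the aromatic nitrogen gives the first measured step at this position in this assay: an at least 4.0-fold higher number from compound 2 to compound 3 (0.60 log units; beyond the scatter). For the compounds shown here, this shows that the change is not silent on this read-out, and that it goes towards weaker inhibition, which no earlier pair could show. The value of compound 3 is a limit and not a number, so the step gives only a lower bound on the size of the change: the limit of > 100000 nM in this assay, at which 2 of the 3 values shown sit.

As far as these compounds go, it remains open whether the weakening belongs to acetyl alone or would follow from other replacements of that hydrogen, such as a methyl group or a longer chain on the same nitrogen. From the compounds shown here alone, it also remains open how far the change would carry over to a core with a different group in place of the hydroxyl.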